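Swapping a Boron Group on Compound 2

The compounds below may be only part of what the source reports. "The series", "measured", "known", "first", "only" and "open" are said of these compounds alone.

- compound 1 `CC1(C)OB(c2ccc(CONC(=O)/C=C/c3cccc(S(=O)(=O)Nc4ccccc4)c3)cc2)OC1(C)C` at 273 nM
- compound 2 `CC1(C)OB(c2cccc(CONC(=O)/C=C/c3cccc(S(=O)(=O)Nc4ccccc4)c3)c2)OC1(C)C` at 8320 nM

In a functional assay on HeLa cells (Homo sapiens) for antiproliferative activity, read by fluorescence and resazurin assay, with a stated time of 72 h (on this read-out lower numbers stand for stronger inhibition and higher numbers for weaker inhibition), compound 2 gives the higher of the two numbers at 8320 nM and so the weaker inhibition. Compound 1 sits at 273 nM on the same scale, a gap well beyond the scatter.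

Compound 3 `O=C(/C=C/c1cccc(S(=O)(=O)Nc2ccccc2)c1)NOCc1cccc(B(O)O)c1` has not been measured yet. It keeps the core of compound 2 and alters one group on an aromatic carbon: a group of 3 heavy atoms (1 boron, 2 oxygen; no ring) in place of a group of 9 heavy atoms (6 carbon, 1 boron, 2 oxygen; one five-membered non-aromatic ring with 3 hetero atoms), on an aromatic carbon is the whole difference. For the measured compounds named here, no measured pair shows this exchange, so the expectation starts from compound 2 at 8320 nM and stays close to it. Any shift is expected to lean slightly towards a lower number and to stay within the scatter. The expected step is a 1.4-fold lower number from compound 2 to compound 3 (0.14 log units; within the scatter) in this assay on this reasoning. For compound 3 the estimate is 6000 nM (expected range 1800 nM to 20000 nM).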

Compound 3, half-maximal inhibitory concentration: 12900 nM
Compound 3: the middle estimate sits 2.2-fold (0.33 log units) below what was measured, within the range that was stated.
By their numbers in this assay, from the lowest: compound 1; then compounds 2 and 3 (each within the scatter of the next).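

In this assay the exchange of the group of 9 heavy atoms, with its five-membered non-aromatic ring, for the ringless group of 3 heavy atoms gives a 1.6-fold higher number from compound 2 to compound 3 (0.19 log units; within the scatter) on this aromatic carbon, meta to a large group. This read-out therefore does not separate the two boron-containing groups at this position, even though the group that enters has 2 hydrogen-bond donors and the group that leaves has 0 hydrogen-bond donors. Nothing available explains this result.

On these data alone, whether the same exchange would also leave the number unmoved on compound 1, which gives 273 nM in this assay and carries its boron group elsewhere on the ring, stays open. As far as these compounds go, it is also open what a group without boron, such as a carboxylic acid or an amine, would do on this aromatic carbon.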